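This account rests on a few compounds, and the source may have more. Where it says the series, first, only, none or still open, it means among the compounds named here.

Compound 2 `COc1ccc(-c2ccc(OCc3cc(C(=O)NS(=O)(=O)c4ccccc4)oc3C)cc2)cc1` stands second highest of the three numbers in an assay on cells for displacement of a labelled ligand from prostaglandin E2 receptor EP4 subtype (Homo sapiens), read by scintillation counting (a higher number here means a weaker inhibitor, a lower number a stronger inhibitor), where compound 2 gives 5 nM. Compound 1 `Cc1oc(C(=O)NS(=O)(=O)c2ccccc2)cc1COc1ccc(-c2ccc(OC(F)F)cc2)cc1` gives 1.3 nM in this assay, and compound 3 `COc1ccc(-c2ccc(OCc3cc(C(=O)NS(=O)(=O)c4ccc(CN)cc4)oc3C)cc2)cc1` gives 100 nM. Compound 4 `CC(=O)c1ccc(-c2ccc(OCc3cc(C(=O)NS(=O)(=O)c4ccccc4)oc3C)cc2)cc1` differs from compound 2 by acetyl in place of methoxy on an aromatic carbon. Among the compounds with values here, the only measured step at that same oxygen-bearing position is a 3.8-fold higher number from compound 1 to compound 2 (0.59 log units; beyond the scatter), a modest change, whereas a 20-fold higher number from compound 2 to compound 3 (1.30 log units; beyond the scatter) concerns a different part of the molecule and bears less on this comparison. A modest shift in either direction is therefore expected, and the estimate for compound 4 is 4 nM, within a range of 1.5 nM to 15 nM, corresponding to an expected step of a 1.3-fold lower number from compound 2 to compound 4 (0.10 log units; within the scatter).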

Compound 4, inhibition constant: 20 nM
Compound 4: the middle estimate sits 5.0-fold (0.70 log units) below what was measured, outside the stated range (above it).
By their numbers in this assay, from the lowest: compound 1; then compound 2; then compound 4; then compound 3.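

Swapping methoxy for acetyl gives a 4.0-fold higher number from compound 2 to compound 4 (0.60 log units; beyond the scatter) in this assay, so this position also responds to a group that is not attached through oxygen, whereas the earlier compounds compared only methoxy and difluoromethoxy there. The step from difluoromethoxy to acetyl is larger, a 15-fold higher number from compound 1 to compound 4 (1.19 log units; beyond the scatter), and acetyl gives the highest number of these three groups. No measurement at hand explains these shifts. On these data alone, how an amine, a carboxylic acid or a longer chain would behave at this position remains open. Within the data shown here, with acetyl the only group here attached through carbon, no rule for such groups can be drawn.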